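Adding an allyl group to compound 1

The source may report more compounds than this note shows. Statements on the series, on what has been measured and on what is new or still open speak of the compounds shown alone.

- compound 1 `O[C@H]1CO[C@H](COCc2ccccc2)[C@@H](OCc2ccccc2)[C@@H]1OCc1ccccc1` – 37900 nM
- compound 2 `CCC[C@H]1O[C@H](COCc2ccccc2)[C@@H](OCc2ccccc2)[C@H](OCc2ccccc2)[C@H]1O` – 23600 nM
- compound 3 `C=CC[C@@H]1O[C@H](COCc2ccccc2)[C@@H](OCc2ccccc2)[C@H](OCc2ccccc2)[C@H]1O` – not yet measured

Among the compounds with values here, in a functional assay on HOS cells (Homo sapiens) for antiproliferative activity, read by sulforhodamine B assay (on this read-out lower numbers stand for stronger inhibition of growth and higher numbers for weaker inhibition of growth), compound 1 gives 37900 nM and stands at the top of the two numbers so far, although its only neighbour, compound 2, lies within the usual scatter of it. Compound 3 is compound 1 with allyl in place of hydrogen on a saturated ring carbon, next to the ring oxygen, and the change in full is allyl in place of hydrogen on a saturated ring carbon on the core of compound 1.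

Within the data shown here, the one measured step that bears on this is a 1.6-fold lower number from compound 1 to compound 2 (0.21 log units; within the scatter), where propyl took the place of hydrogen on a saturated ring carbon. That step is too small to tell apart from repeat measurements. Allyl has a double bond that propyl lacks, and no measured compound shows what it does here. So no step beyond the scatter is expected in this assay, and the data favour no direction. The expected move is a 1.4-fold lower number from compound 1 to compound 3 (0.15 log units; within the scatter) and no more than that. For compound 3 the estimated value is 27000 nM, with an expected range from 11000 nM to 65000 nM as its likely span.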

Compound 3, concentration for 50% growth inhibition: 44100 nM
Compound 3: the middle estimate sits 1.6-fold (0.21 log units) below what was measured; the range from low to high includes it.
By their numbers in this assay, from the lowest: compounds 2, 1 and 3 (each within the scatter of the next).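

In this assay, allyl in place of hydrogen on the saturated ring carbon next to the ring oxygen brings a 1.2-fold higher number from compound 1 to compound 3 (0.07 log units; within the scatter) and so leaves the number where it was, as far as repeat measurements can tell. The earlier propyl step, a 1.6-fold lower number from compound 1 to compound 2 (0.21 log units; within the scatter) in the same assay, was also too small to read, so now two different three-carbon chains at this place on the core of compound 1 show no change that stands out from the scatter. With only these steps, the compounds shown give no sign that this ring carbon controls growth inhibition in these cells, and no measurement is available to explain why the number stays put.

On these data alone, whether this position responds at all remains open, since an amine, a carboxylic acid or a longer chain such as hexyl on this carbon could still give a step beyond the scatter. Also unsettled is whether the ring atom that bears a hydroxy group, or any of the benzyloxy groups, matters more to the activity than this carbon does.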